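Cytotoxicity of a pyrazoline sulfonamide series: a fluorophenyl analogue

This account rests on a few compounds, and the source may have more. Where it says the series, first, only, none or still open, it means among the compounds named here.

Of the compounds shown here, three of one series have been measured for tolerance in an ADME assay on BHK-21 cells (Mesocricetus auratus) for cytotoxicity, read by MTT assay, with a stated time of 72 h; a higher number here means that more compound is tolerated, a lower number that less compound is tolerated. Compound 1 `NS(=O)(=O)c1ccc(N2N=C(c3ccc(Oc4ccccc4)cc3)CC2c2ccccc2F)cc1` gives 32000 nM, compound 2 `NS(=O)(=O)c1ccc(N2N=C(c3ccc(Oc4ccccc4)cc3)CC2c2ccccc2)cc1` gives 11000 nM, and compound 3 `Cc1ccccc1C1CC(c2ccc(Oc3ccccc3)cc2)=NN1c1ccc(S(N)(=O)=O)cc1` gives 7000 nM. Compound 3 thus gives the lowest of the three numbers; its value sits within the scatter of that of compound 2, since a 1.6-fold lower number from compound 2 to compound 3 (0.20 log units; within the scatter), but well apart from that of compound 1, since a 4.6-fold lower number from compound 1 to compound 3 (0.66 log units; beyond the scatter).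

Compound 4 `NS(=O)(=O)c1ccc(N2N=C(c3ccc(Oc4ccccc4)cc3)CC2c2cccc(F)c2)cc1` has not yet been measured. It differs from compound 3 in one place: 3-fluorophenyl in place of 2-methylphenyl on a saturated ring carbon.

Within the data shown here, the steps that bear on this change are those that remove a fluoro from an aromatic carbon of compound 1, namely a 2.9-fold lower number from compound 1 to compound 2 (0.46 log units; beyond the scatter) and a 4.6-fold lower number from compound 1 to compound 3 (0.66 log units; beyond the scatter). In both, the compound without fluoro tolerates less. Among the measured compounds shown here, compound 4 carries fluoro again, though as 3-fluorophenyl rather than the 2-fluorophenyl of compound 1, so the account gives no direct precedent for this arrangement. On that basis a higher number than for compound 3 is expected, roughly reversing the step from compound 1, with a 2.6-fold higher number from compound 3 to compound 4 (0.41 log units; beyond the scatter) as the expected change. The estimate for compound 4 in this assay is 18000 nM, with a range from 7000 nM to 45000 nM.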

Compound 4, half-maximal cytotoxic concentration: 10000 nM
Compound 4: middle estimate off by 1.8-fold (0.26 log units), on the high side; the range from low to high includes it.
By their numbers in this assay, from the lowest: compounds 3, 4 and 2 (each within the scatter of the next); then compound 1.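

In this assay, replacing 2-methylphenyl with 3-fluorophenyl on the saturated ring carbon gives a 1.4-fold higher number from compound 3 to compound 4 (0.15 log units; within the scatter), and the step that only adds a fluoro gives a 1.1-fold lower number from compound 2 to compound 4 (0.04 log units; within the scatter), so neither change separates these compounds beyond the scatter. The step that does exceed the scatter is the one that changes only where the fluoro sits on the phenyl ring, 3-fluorophenyl in place of 2-fluorophenyl, with a 3.2-fold lower number from compound 1 to compound 4 (0.51 log units; beyond the scatter); at this position, then, the presence of a fluoro does not by itself go with the high tolerated concentration, which among these compounds is seen only with 2-fluorophenyl. Nothing available explains why the placement of the fluoro matters in this series.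

The compounds shown leave open whether the higher number is particular to 2-fluorophenyl or would also appear with a chlorophenyl, methoxyphenyl or difluorophenyl group on the same saturated ring carbon. They also leave open whether the same difference would appear with a carboxylic acid or an amine on that phenyl ring.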